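A few compounds are considered here, and "the series" means these few. Any claim that something is new, unique, unknown or untested is made for them only; others in the source may bear on it.

Measured compounds in a physicochemical assay for solubility, measured as kinetic solubility, at pH 2; a higher number here means a more soluble compound, a lower number a less soluble compound:
compound 1 `CC(C)(/C=C1\OC(=O)NC1=O)c1ccc(-c2ccc3cccc(F)c3c2)[nH]c1=O`: 1660 nM
compound 2 `CC(C)C(c1ccc(-c2ccc3cccc(F)c3c2)[nH]c1=O)C1C(=O)NC(=O)N1C`: 13600 nM
compound 3 `CC(C)[C@@H](c1ccc(-c2ccc3cccc(F)c3c2)[nH]c1=O)[C@@H]1OC(=O)NC1=O`: 6900 nM

Compound 2 stands highest of the three numbers in this assay. Its nearest neighbour is compound 3, whose value lies within the scatter of repeated measurement, so no order between compound 2 and compound 3 can be read from these two. Compound 1 sits furthest from compound 2, at a gap beyond the scatter.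

The unmeasured compound 4 `CC(C)C(CC1C(=O)NC(=O)N1C)c1ccc(-c2ccc3cccc(F)c3c2)[nH]c1=O` differs from compound 2 in one place:
(3-methyl-2,5-dioxoimidazolidin-4-yl)methyl in place of 3-methyl-2,5-dioxoimidazolidin-4-yl on a saturated chain carbon bound to an aromatic carbon and a saturated chain carbon
The ring itself, its two carbonyls, its hydrogen-bond donor and its hydrogen-bond acceptors are kept; the change is the insertion of one saturated carbon between the chain carbon and the ring. Within the data shown here, no measured pair in this set shows a step of this kind, so the direction cannot be taken from a prior step. With the same ring and the same count of donors and acceptors retained, the step from compound 2 to compound 4 is expected to be small, likely none beyond the scatter, with the estimated step of a 1.1-fold lower number from compound 2 to compound 4 (0.05 log units; within the scatter) in this assay. Compound 4 is therefore estimated at 12000 nM, within a range from 5000 nM to 30000 nM.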

Compound 4, solubility: 26600 nM
Beside the measured number, compound 4's estimate is 2.2-fold (0.35 log units) below it; low and high end bracket the measured number.
By their numbers in this assay, from the lowest: compound 1; then compounds 3, 2 and 4 (each within the scatter of the next, the first and the last beyond it).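

In this assay the place on a saturated chain carbon bound to an aromatic carbon and a saturated chain carbon accepts (3-methyl-2,5-dioxoimidazolidin-4-yl)methyl in place of 3-methyl-2,5-dioxoimidazolidin-4-yl with a 2.0-fold higher number from compound 2 to compound 4 (0.29 log units; within the scatter) as the step, the first one-place step available in this series. The read-out therefore does not separate the ring attached directly from the ring held one saturated carbon further out, and no order between the two compounds can be taken from this pair. No measurement is at hand that would explain this result.

On these data alone, whether a longer chain at this place would also stay within the scatter of compound 2 remains open. So does the outcome of replacing the ring there with a carboxylic acid or an amine, and a single step on one ring says nothing yet about the same insertion on the ring of compound 3.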